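Side-chain change at the amino acid position of an oral analgesic

A few compounds are considered here, and "the series" means these few. Any claim that something is new, unique, unknown or untested is made for them only; others in the source may bear on it.

Among the measured compounds shown here, compound 2 `CC(C)[C@H](NC(=O)CN(c1nc(Cl)nc2[nH]cnc12)C1CC1)C(=O)O` is one of two compounds measured in a functional assay on the whole organism (Tail, strain ICR) with Mus musculus as the target, in the tail flick test, with a stated time of 30 min, at a dose of 25 umol/kg by the oral route (on this read-out lower numbers stand for a weaker effect and higher numbers for a stronger effect at the one dose given), where compound 2 gives 31.2%. For the measured compounds named here, its only neighbour, compound 1 `NCCCC[C@H](NC(=O)CN(c1nc(Cl)nc2[nH]cnc12)C1CC1)C(=O)O`, gives 31.2% in this assay, and the step of no change at the digits printed from compound 1 to compound 2 (within the scatter) shows that exchanging one side chain for another on the saturated chain carbon bound to an amide-type nitrogen and a carbonyl carbon left the read-out unchanged. Compound 3 `NC(=O)CC[C@H](NC(=O)CN(c1nc(Cl)nc2[nH]cnc12)C1CC1)C(=O)O` is the next variation at that position: 2-carbamoylethyl in place of isopropyl on a saturated chain carbon bound to an amide-type nitrogen and a carbonyl carbon. Going by the values given here, the one measured step that bears on this change is the one from compound 1 to compound 2, which lay within the scatter, and it gives no reason to expect movement here, so the step of a number 0.2 percentage points lower from compound 2 to compound 3 (within the scatter) is expected to stay within the scatter. Compound 3 is therefore estimated to give 31% in this assay, with a range of 14% to 48%.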

Compound 3, a percentage reported as activity, at one dose (the size of the read-out at that dose, not a potency): 33.1%
The estimate for compound 3 lay 2.1 percentage points below the measured number, and the stated range covers the measured number.
By their numbers in this assay, from the lowest: compounds 1, 2 and 3 (each within the scatter of the next).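

Across this assay the step to 2-carbamoylethyl, a number 1.9 percentage points higher from compound 2 to compound 3 (within the scatter), adds a second case to the earlier isopropyl result, and this time the entering group carries a hydrogen-bond donor and a hydrogen-bond acceptor where isopropyl has neither. The other step, a number 1.9 percentage points higher from compound 1 to compound 3 (within the scatter), also stays within the scatter, so 4-aminobutyl, isopropyl and 2-carbamoylethyl on the saturated chain carbon bound to an amide-type nitrogen and a carbonyl carbon cannot be told apart at this one dose. No measurement at hand offers an explanation for this flat result.

Still open, as far as these compounds go, is whether a side chain ending in a carboxylic acid, or a benzyl group, would leave the scatter at this position. With a single dose and a single time, these compounds also leave their relative potency undefined.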